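Butyl chain and methylphenyl combined on an inactive pair

The compounds below may be only part of what the source reports. "The series", "measured", "known", "first", "only" and "open" are said of these compounds alone.

Compound 1, `CCCCc1cc2ccccc2nc1-c1cc(-c2ccccc2)no1`, in a functional assay on A549 cells (Homo sapiens) for inhibition, read by MTT assay, with a stated time of 24 h (on this read-out higher numbers stand for weaker inhibition and lower numbers for stronger inhibition), gives > 100000 nM, which is a limit of the assay and not a number.
Compound 2, `CCc1cc2ccccc2nc1-c1cc(-c2ccc(C)cc2)no1`, in this assay gives > 100000 nM, likewise a limit of the assay.

Compound 2 therefore stands only at a limit, as does the other value shown; both sit at the limit of > 100000 nM in this assay, at which 2 of the 2 values shown sit. Within the data shown here, no measured step links compound 1 and compound 2, so nothing about the size of any change can be read from their two values. Compound 3, `CCCCc1cc2ccccc2nc1-c1cc(-c2ccc(C)cc2)no1`, differs from compound 2 by ethyl in place of hydrogen on a saturated chain carbon, two bonds along the chain from an aromatic carbon, in words ethyl in place of hydrogen on a saturated chain carbon, two bonds along the chain from an aromatic carbon. Since compound 1 carries this same butyl chain and also reaches only the limit, compound 3 is expected to stay at the limit, with an estimate of 150000 nM and a range from 50000 nM to 500000 nM. The implied step, a step that the limit leaves unreadable from compound 2 to compound 3, is expected to be none beyond the scatter.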

Compound 3, half-maximal inhibitory concentration: > 100000 nM
Compound 3 gave a limit, no number (the forecaster's own chance of this, stated with the estimate: 85%); the middle value is on the limit's open side.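

Compound 3 also stands at a limit of the assay, not a number, so the steps to it from compound 1 and from compound 2 cannot be read: the limit of > 100000 nM in this assay, at which 3 of the 3 values shown sit.

The compounds shown leave open how far the ethyl or butyl chain, or the methyl group, bears on inhibition in this assay, with no compound here giving a number.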